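The source may report more compounds than this note shows. Statements on the series, on what has been measured and on what is new or still open speak of the compounds shown alone.

Values from an ADME assay on CHO cells (Cricetulus griseus) for cytotoxicity, read by LDH release (a higher number here means a weaker inhibitor, a lower number a stronger inhibitor), for each compound
Compound 1 `CC(Oc1ccc(Cl)cc1Cl)C(=O)OCc1ccc(F)cc1` gives "not determined" (no result reported)
Compound 2 `CC(Oc1ccc(Cl)cc1Cl)C(=O)NCc1cccc(F)c1` gives 27000 nM
Compound 3 `CC(Oc1ccc(Cl)cc1Cl)C(=O)NCc1cccc(Cl)c1` gives 19000 nM
Compound 4 `Cc1cccc(CNC(=O)C(C)Oc2ccc(Cl)cc2Cl)c1` awaits measurement

Going by the values given here, only two of the measured compounds carry a number, since compound 1 has no result to compare. Compound 3 at 19000 nM stands within the scatter of compound 2, so the two cannot be told apart in this assay on these data.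

Compound 4 has methyl in place of chloro on an aromatic carbon and this turns 3-chlorophenyl into 3-methylphenyl. Among the compounds with values here, no measured compound yet carries this methyl, so the evidence is indirect. Within the data shown here, the one measured step that bears on it is a 1.4-fold lower number from compound 2 to compound 3 (0.15 log units; within the scatter) and it also exchanges a single group on an aromatic carbon. That step is small, so a similarly small one is expected here, with nothing beyond the scatter. The expected step is a 1.2-fold higher number from compound 3 to compound 4 (0.06 log units; within the scatter) as a rough estimate. For compound 4 the estimated value is 22000 nM with an expected range from 10000 nM to 45000 nM as the likely span.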

Compound 4, half-maximal inhibitory concentration: 45000 nM
The estimate for compound 4 lay 2.0-fold (0.31 log units) below the measured number; the measured number falls inside the stated range.
By their numbers in this assay, from the lowest: compounds 3, 2 and 4 (each within the scatter of the next, the first and the last beyond it).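

In this assay the earlier fluoro and chloro pair could not be told apart at this aromatic carbon, but methyl in place of chloro gives a 2.4-fold higher number from compound 3 to compound 4 (0.37 log units; beyond the scatter) and so shows that the group here can shift the number, if only modestly. Methyl in place of fluoro gives a 1.7-fold higher number from compound 2 to compound 4 (0.22 log units; within the scatter) and so stays unresolved, which means that chloro and methyl are the only pair of these three groups that can be separated. Nothing measured here accounts for that difference.

As far as these compounds go, it remains open how an amine, a carboxylic acid or a longer chain at this same carbon would compare with chloro and methyl. From the compounds shown here alone, it is also open whether the exchange of chloro for methyl would give a similar step at another carbon of this ring.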